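Swapping pyridin-3-yl for phenyl on a carbonyl carbon

The source may hold more compounds than are shown below. What is called first, only, known or untested is meant among the compounds shown, and "the series" means these compounds.

- Compound 1 `CC(C)(C)C(=O)N1N=CCC1c1ccccn1` gives 3.5
- Compound 2 `O=C(c1cccnc1)N1N=CCC1c1ccccc1` gives 2.7

In a physicochemical assay for lipophilicity, read by HPLC, measured as chromatographic lipophilicity, at pH 7.4 (on this read-out lower numbers stand for lower lipophilicity and higher numbers for higher lipophilicity), compound 2 gives 2.7, the lower of the two numbers, while compound 1 sits at 3.5, a gap beyond the usual scatter. Compound 3 `O=C(c1ccccc1)N1N=CCC1c1ccccc1` makes a single change to compound 2, phenyl in place of pyridin-3-yl on a carbonyl carbon. For the measured compounds named here, no measured pair of compounds isolates this change, so what follows is judgement only. The expected step, a number 0.90 log units higher from compound 2 to compound 3 (beyond the scatter), is a rise beyond the scatter. Compound 3 is estimated at 3.6, with an expected range from 3.2 to 4.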

Compound 3, distribution coefficient: 4.6
For compound 3 the middle estimate is 1.00 log units below the measured one, and the stated range ends below it.
By their numbers in this assay, from the lowest: compound 2; then compound 1; then compound 3.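

For the compounds shown here, compound 2 and compound 3 are the only pair here that differs in one place, so this position can now be read directly. In this assay, going by these compounds alone, phenyl in place of pyridin-3-yl on a carbonyl carbon gives a number 1.90 log units higher from compound 2 to compound 3 (beyond the scatter), a large step for a swap that keeps the heavy-atom count and loses only one ring nitrogen, a hydrogen-bond acceptor. Nothing measured here explains the size of this step. Still open, on these data alone, is where cyclohexyl, or a phenyl carrying a methoxy group or an amine, would fall at this position. One pair also cannot show whether the step holds on another core.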